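A few compounds are considered here, and "the series" means these few. Any claim that something is new, unique, unknown or untested is made for them only; others in the source may bear on it.

Measured in a functional assay on MDA-MB-231 cells (Homo sapiens) for inhibition, read by MTT assay, with a stated time of 48 h; on this read-out higher numbers stand for weaker inhibition of growth and lower numbers for stronger inhibition of growth:
- Compound 1 `N=C(N)NS(=O)(=O)c1ccc(Nc2ncnc3ccc(NC(=S)NCc4ccccc4)cc23)cc1`: > 30000 nM
- Compound 2 `S=C(Nc1ccccc1)Nc1ccc2ncnc(Nc3cccc(Br)c3)c2c1`: 10000 nM

Compound 1 gives > 30000 nM, which is a limit of the assay and not a number. Among the measured compounds shown here, that leaves compound 2, at 10000 nM, as the only true number so far, and with a single number no ranking can be drawn.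

Compound 3 `FC(F)(F)c1cc(NC(=S)Nc2ccc3ncnc(Nc4cccc(Br)c4)c3c2)ccc1Cl` keeps the rest of compound 2 but has 4-chloro-3-(trifluoromethyl)phenyl in place of phenyl on an amide-type nitrogen.

For the measured compounds named here, no measured pair of compounds shows what such a swap does in this assay, so any forecast is uncertain and the range must stay wide. A moderate gain in inhibition of growth is expected, starting from compound 2 at 10000 nM. The expected change is a 2.5-fold lower number from compound 2 to compound 3 (0.40 log units; beyond the scatter). For compound 3 the estimated value is 4000 nM, with an expected range of 1000 nM to 15000 nM.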

Compound 3, concentration for 50% growth inhibition: 1100 nM
Estimate against measurement, compound 3: 3.6-fold (0.56 log units) above; the measured number falls inside the stated range.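

Compared with compound 2, compound 3 shows that the ring on this amide-type nitrogen affects growth inhibition in this assay: placing 4-chloro-3-(trifluoromethyl)phenyl there instead of phenyl gives a 9.1-fold lower number from compound 2 to compound 3 (0.96 log units; beyond the scatter). The rest of compound 2 stays the same, so this step reads one position only, and the larger group is clearly tolerated there. The comparison uses two true numbers, and neither compound sits at the limit of the assay: the limit of > 30000 nM in this assay, at which 1 of the 3 values shown sits.

This single pair leaves open whether the chlorine, the trifluoromethyl or the two together account for the gain, which 4-chlorophenyl and 3-(trifluoromethyl)phenyl would help separate. Also open, from the compounds shown here alone, is what a ring bearing a carboxylic acid, or a short alkyl chain in place of the ring, would do on this nitrogen.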